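Halogen swap flat, semicarbazide-type extension untested

This account rests on a few compounds, and the source may have more. Where it says the series, first, only, none or still open, it means among the compounds named here.

Among the compounds with values here, in a functional assay on MIA PaCa-2 cells (Homo sapiens) for inhibition, read by MTT assay, with a stated time of 72 h (on this read-out lower numbers stand for stronger inhibition and higher numbers for weaker inhibition), compound 1 (`COc1cc(NC(C)CCCNC(=O)Nc2cccc(F)c2)c2ncccc2c1`) gives 22000 nM and compound 2 (`COc1cc(NC(C)CCCNC(=O)Nc2ccc(Br)cc2)c2ncccc2c1`) gives 23000 nM, so compound 2 stands level with the only other measured compound. The next structure is compound 3 (`COc1cc(NC(C)CCCNC(=O)NNC(=O)Nc2ccc(F)cc2)c2ncccc2c1`), reached through ((4-fluorophenyl)carbamoyl)amino in place of 4-bromophenyl on an amide-type nitrogen. Within the data shown here, only one measured step bears on this change. That step, a 1.0-fold higher number from compound 1 to compound 2 (0.02 log units; within the scatter), lies within the scatter, but it only exchanges 3-fluorophenyl for 4-bromophenyl. Among the measured compounds shown here, no measured compound carries the larger group, so the data support no direction, and no shift beyond the scatter is expected in this assay, though with low confidence. The expected change is a 1.2-fold lower number from compound 2 to compound 3 (0.06 log units; within the scatter). For compound 3 the estimated value is 20000 nM, with an expected range of 5000 nM to 70000 nM.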

Compound 3, half-maximal inhibitory concentration: >= 250000 nM
Compound 3 ended at the assay's limit; the forecaster's own chance of this, stated with the estimate: 15%; at least 12-fold (1.09 log units) between middle value and limit.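

In this assay compound 3 gives >= 250000 nM, which is a limit of the assay and not a number. On an amide-type nitrogen, ((4-fluorophenyl)carbamoyl)amino weakens inhibition clearly, which the exchange of 3-fluorophenyl for 4-bromophenyl did not show: an at least 10-fold higher number from compound 2 to compound 3 (1.03 log units; beyond the scatter) and an at least 11-fold higher number from compound 1 to compound 3 (1.05 log units; beyond the scatter). This position therefore does respond to a change of group, although the full size of the loss cannot be read from a value that stops at: the limit of >= 250000 nM in this assay, at which 1 of the 3 values shown sits.

The compounds shown leave open which part of the entering group carries the loss. A benzyl group or a plain alkyl chain on the same nitrogen would test size apart from the added nitrogen and carbonyl, and would also show whether any group here gives stronger inhibition than the two aryl compounds.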